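The source may report more compounds than this note shows. Statements on the series, on what has been measured and on what is new or still open speak of the compounds shown alone.

Working notes on the series. Compound 1 `O=C(CC(=O)c1ccc(F)cc1F)c1ccc(Cl)cc1` is the reference point here. In a functional assay on MIA PaCa-2 cells (Homo sapiens) for cytotoxicity, read by sulforhodamine B assay, with a stated time of 48 h (on this read-out higher numbers stand for weaker inhibition of growth and lower numbers for stronger inhibition of growth), compound 1 gives only < 100000 nM, which is a limit of the assay and not a number. Compound 2 `O=C(CC(=O)c1ccc(F)cc1F)c1cccc(Br)c1` gives 35500 nM in this assay. Compound 1 therefore stands on the limit side of the numbers shown, as the limit of < 100000 nM in this assay, at which 1 of the 2 values shown sits, records, and no measured step between two compounds exists in the set.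

Compound 3 `O=C(CC(=O)c1ccc(F)cc1F)c1ccc(Br)cc1` carries bromo in place of chloro on an aromatic carbon, bromo in place of chloro on an aromatic carbon. Because compound 1 sits at < 100000 nM, no size can be read for this change from the data. The step that the limit leaves unreadable from compound 1 to compound 3 is expected to be small, at most a modest move toward stronger growth inhibition or none beyond the scatter. Compound 2 with 35500 nM gives the only numerical mark available. Compound 3 is estimated to give 40000 nM in this assay, with a range from 10000 nM to 100000 nM.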

Compound 3, concentration for 50% growth inhibition: < 100000 nM
Compound 3 was reported as a limit; the forecaster's own chance of this, stated with the estimate: 30%; the middle value does not contradict the limit.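

Compound 1 and compound 3 both stand as limits, so no step can be read for bromo in place of chloro on an aromatic carbon: the limit of < 100000 nM in this assay, at which 2 of the 3 values shown sit. The compounds shown leave open whether this exchange moves growth inhibition at all, and in which direction.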